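A few compounds are considered here, and "the series" means these few. Any claim that something is new, unique, unknown or untested is made for them only; others in the source may bear on it.

Among the measured compounds shown here, the three compounds measured so far share one core. Compound 1 `Oc1c(Cc2cccc(Oc3ccccc3)c2)ccc2ccccc12` gives 83 nM in an assay on RBL-1 cells with Polyunsaturated fatty acid 5-lipoxygenase (Rattus norvegicus) as the target; on this read-out lower numbers stand for stronger inhibition and higher numbers for weaker inhibition. Compound 2 `CC(=O)c1cc(Cc2ccccc2)c(O)c2ccccc12` gives 510 nM in this assay, and compound 3 `O=C(O)c1cc(Cc2ccccc2)c(O)c2ccccc12` gives 5800 nM, the highest of the three numbers, lying furthest from compound 1. For the measured compounds named here, the one measured step that touches this part of the core is an 11-fold higher number from compound 2 to compound 3 (1.06 log units; beyond the scatter), a large move to a weaker read-out.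

Compound 4 `CS(=O)(=O)c1cc(Cc2ccccc2)c(O)c2ccccc12` is the next member. It differs from compound 3 by methylsulfonyl in place of carboxy on an aromatic carbon. Going by the values given here, no measured pair shows this exact exchange; the only guide is that the group which leaves is the same carboxy whose arrival caused the large step from compound 2 to compound 3, so removing it is expected to pull the number back toward that of compound 2, though by how much cannot be read from the existing pairs. The step from compound 3 to compound 4 is therefore expected to be a 3.9-fold lower number from compound 3 to compound 4 (0.59 log units; beyond the scatter). Compound 4 is accordingly estimated at 1500 nM, within a range from 300 nM to 8000 nM.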

Compound 4, half-maximal inhibitory concentration: 40000 nM
Beside the measured number, compound 4's estimate is 27-fold (1.43 log units) below it, outside the stated range (above it).
By their numbers in this assay, from the lowest: compound 1; then compound 2; then compound 3; then compound 4.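

Three groups have now been read para to the hydroxy group, and in this assay the number climbs from acetyl to carboxy to methylsulfonyl, so the carboxy of compound 3 does not mark the weak end of this position: there is a 6.9-fold higher number from compound 3 to compound 4 (0.84 log units; beyond the scatter). Measured against the acetyl, the change is far larger, with a 78-fold higher number from compound 2 to compound 4 (1.89 log units; beyond the scatter), which shows that this one position can move the read-out widely depending on the group it carries. No measurement here explains this order.

The compounds shown leave open whether a plain hydrogen, an amine or a methyl ester at this position would give a lower number than the acetyl of compound 2. They also leave open whether the same order would hold with the benzyl group of compound 1.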